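Taking One Trifluoromethyl Off the Hydrazone End

The source may hold more compounds than are shown below. What is called first, only, known or untested is meant among the compounds shown, and "the series" means these compounds.

Compound 2 `CN(C(=O)NC(=O)c1c(F)cccc1F)c1nc(C(F)(F)F)c(C(=O)N/N=C/c2cc(C(F)(F)F)cc(C(F)(F)F)c2)s1` is the starting point here. In a functional assay on A549 cells (Homo sapiens) for inhibition, read by MTT assay, with a stated time of 72 h (on this read-out lower numbers stand for stronger inhibition and higher numbers for weaker inhibition), compound 2 gives 17.3 ug/mL, the higher of the two plain numbers known. Compound 1 `CN(C(=O)NC(=O)c1ccccc1F)c1nc(C(F)(F)F)c(C(=O)N/N=C/c2ccccc2C(F)(F)F)s1`, which differs in several places, gives 6.32 ug/mL in this assay, and the gap to compound 2 is beyond the usual scatter. Compound 3 `CNc1nc(C(F)(F)F)c(C(=O)N/N=C/c2ccc(C(F)(F)F)cc2)s1` reaches only a limit in this assay, > 100 ug/mL. Compound 4 `CN(C(=O)NC(=O)c1c(F)cccc1F)c1nc(C(F)(F)F)c(C(=O)N/N=C/c2cccc(C(F)(F)F)c2)s1` has not yet been measured; it differs from compound 2 by hydrogen in place of trifluoromethyl on an aromatic carbon. Within the data shown here, no measured pair shows this exact change. The expected step is small, a move of a 1.4-fold lower number from compound 2 to compound 4 (0.16 log units; within the scatter), with compound 4 expected to land near compound 2 or a little lower. The estimate for compound 4 is 12 ug/mL, with a range from 5 ug/mL to 30 ug/mL.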

Compound 4, half-maximal inhibitory concentration: 27.6 ug/mL
Compound 4: the middle estimate sits 2.3-fold (0.36 log units) below what was measured; low and high end bracket the measured number.
By their numbers in this assay, from the lowest: compound 1; then compounds 2 and 4 (each within the scatter of the next). At a limit, above all of these: compound 3.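

Among these compounds, the step of a 1.6-fold higher number from compound 2 to compound 4 (0.20 log units; within the scatter) is the first reading of this change, and it shows that the ring keeps a similar number in this assay with one trifluoromethyl in place of two. Compound 3 gives only a limit and differs from compound 4 in several places, so it offers no step to set beside this one: the limit of > 100 ug/mL in this assay, at which 1 of the 4 values shown sits.

As far as these compounds go, whether an amine or a chlorine in this place would shift the number stays open. So does the effect of taking the remaining trifluoromethyl off the ring of compound 4.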